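Methyl shift on the aromatic nitrogen substituent

This account rests on a few compounds, and the source may have more. Where it says the series, first, only, none or still open, it means among the compounds named here.

Among the measured compounds shown here, in a functional assay on MDA-MB-231 cells (Homo sapiens) for antiproliferative activity, read by MTT assay, with a stated time of 72 h (a higher number here means a weaker inhibitor, a lower number a stronger inhibitor), compound 1 `CCCCCn1ccnc1-c1cc(OC)c(OC)c(OC)c1` gives 34200 nM, while compound 2 `COc1cc(-c2nccn2-c2ccc(C)cc2)cc(OC)c1OC` gives 4100 nM, the lower of the two numbers so far. Compound 3 `COc1cc(-c2nccn2-c2cccc(C)c2)cc(OC)c1OC` is not yet measured. It has 3-methylphenyl in place of 4-methylphenyl on an aromatic nitrogen. For the measured compounds named here, the only measured step, an 8.3-fold lower number from compound 1 to compound 2 (0.92 log units; beyond the scatter), exchanged pentyl for 4-methylphenyl, a different kind of change from this one, so a step of that size is not carried over. The expected step is a 1.1-fold higher number from compound 2 to compound 3 (0.04 log units; within the scatter), with nothing beyond the scatter anticipated in either direction. For compound 3 the estimated value is 4500 nM, with a range of 1600 nM to 12000 nM.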

Compound 3, half-maximal inhibitory concentration: 11700 nM
Compound 3: middle estimate off by 2.6-fold (0.41 log units), on the low side; the range from low to high includes it.
By their numbers in this assay, from the lowest: compound 2; then compound 3; then compound 1.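

Among the compounds shown here, on the aromatic nitrogen, the position of the methyl on the phenyl ring matters: in this assay there is a 2.9-fold higher number from compound 2 to compound 3 (0.46 log units; beyond the scatter) even though both groups have the same heavy atoms, so the 4-methylphenyl group gives the lowest number of the series so far. The 3-methylphenyl group still keeps an advantage over pentyl (a 2.9-fold lower number from compound 1 to compound 3 (0.47 log units; beyond the scatter)). Nothing measured here accounts for the difference between the two methylphenyl groups.

Left open is how an unsubstituted phenyl would read at this position. Also open, on these data alone, is whether a chlorine or an amine in place of the methyl would show the same dependence on position.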